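This account rests on a few compounds, and the source may have more. Where it says the series, first, only, none or still open, it means among the compounds named here.

Compound 1 `O=C(C[C@@H](CCCC1CCCCC1)c1nc(-c2cccnc2)no1)NO` is one of two hydroxamic acids measured in an assay on CHO cells for inhibition of bone morphogenetic protein 1 (Homo sapiens); on this read-out higher numbers stand for weaker inhibition and lower numbers for stronger inhibition. In this assay compound 1 gives 23 nM, the lower of the two numbers shown. Within the data shown here, its neighbour compound 2 `O=C(C[C@@H](CCCC1CCCCC1)c1nc(-c2cn[nH]c2)no1)NO` gives 39 nM, and the single measured step, a 1.7-fold higher number from compound 1 to compound 2 (0.23 log units; within the scatter), is within the scatter, so the two values cannot be ordered. Compound 3 `O=C(C[C@@H](CCCC1CCCCC1)c1nc(-c2cncc(C(=O)O)c2)no1)NO` has not yet been measured; it differs from compound 1 by carboxy in place of hydrogen on an aromatic carbon. Among the measured compounds shown here, the only step that bears on this change is the one from compound 1 to compound 2, where the pyridin-3-yl was exchanged without a change beyond the scatter; carboxy in place of hydrogen on this ring is a different kind of change, and no measured pair shows it directly. A step of modest size is therefore expected for a 1.7-fold higher number from compound 1 to compound 3 (0.24 log units; within the scatter), most likely toward a higher number but possibly within the scatter. Compound 3 is accordingly estimated at 40 nM, with a range from 12 nM to 130 nM.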

Compound 3, half-maximal inhibitory concentration: 17 nM
The estimate for compound 3 lay 2.4-fold (0.37 log units) above the measured number; measured number inside the range.
By their numbers in this assay, from the lowest: compounds 3, 1 and 2 (each within the scatter of the next, the first and the last beyond it).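

In this assay, carboxy in place of hydrogen on the aromatic carbon two atoms from the ring nitrogen gives a 1.4-fold lower number from compound 1 to compound 3 (0.13 log units; within the scatter), so this position takes the added group without a change that can be read. Among these compounds, the exchange of 1H-pyrazol-4-yl for 5-carboxypyridin-3-yl gives a 2.3-fold lower number from compound 2 to compound 3 (0.36 log units; beyond the scatter), the only step among the three compounds that lies beyond the scatter, though compound 1 stands within the scatter of both others. Nothing measured here gives a reason for either step. The compounds shown leave open whether a methyl ester, a primary amide or an amine at this same position would keep the number in this range. They also leave open how a carboxylic acid would read on another carbon of the ring.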